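Anilide ring swap on the shared core: expected cytotoxicity

The source may hold more compounds than are shown below. What is called first, only, known or untested is meant among the compounds shown, and "the series" means these compounds.

Compound 1 `Cc1cccc(NC(=O)c2cccc(/C=C3\CC(=O)N(c4ccccc4)C3=O)c2)c1` was tested in an ADME assay on SW480 cells (Homo sapiens) for cytotoxicity, read by MTT assay, with a stated time of 72 h (on this read-out lower numbers stand for stronger inhibition and higher numbers for weaker inhibition), and gave a value of > 100000 nM, which is a limit of the assay rather than a number. Compound 2 `COc1cc(NC(=O)c2cccc(/C=C3\CC(=O)N(c4ccccc4)C3=O)c2)cc(OC)c1OC` sits likewise at a limit in this assay, with > 100000 nM. Compound 3 `CCCCCN1C(=O)C/C(=C\c2cccc(C(=O)Nc3ccc(OC)cc3)c2)C1=O` also returns only a limit in this assay, > 100000 nM. Within the data shown here, every value so far rests on (the limit of > 100000 nM in this assay, at which 3 of the 3 values shown sit), so compound 1 cannot be placed above or below any other measured compound; it stands with all of them at the limit, and no step between measured compounds is available.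

Compound 4 `CCOc1ccc(NC(=O)c2cccc(/C=C3\CC(=O)N(c4ccccc4)C3=O)c2)cc1` is the next compound, not yet measured in this assay. It differs from compound 1 by 4-ethoxyphenyl in place of 3-methylphenyl on an amide-type nitrogen. Compound 3 already carries a 4-methoxyphenyl on its amide-type nitrogen, with a different group on the other ring nitrogen, and it too gives only a limit; nothing in the series therefore points to a gain in potency from a 4-alkoxyphenyl anilide. For compound 4 no step beyond the scatter is expected, and the expected step is a number no higher from compound 1 to compound 4 (the limit leaves the size open). Compound 4 is estimated at 100000 nM, with a range from 50000 nM to 300000 nM, most likely again reported as a limit.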

Compound 4, half-maximal inhibitory concentration: 91500 nM
The estimate for compound 4 lay 1.1-fold (0.04 log units) above the measured number; the measured number falls inside the stated range.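

In this assay, compound 4 is the only compound shown that gives a number rather than a limit, so this position on the amide-type nitrogen can carry a group that brings a reading inside the measurable range. The change to 4-ethoxyphenyl in place of 3-methylphenyl gives an at least 1.0-fold lower number from compound 1 to compound 4 (0.03 log units; that floor lies within the scatter), and only this floor can be read, so the data show no gain beyond the scatter and do not fix the true size of the step. Among these compounds, the single number does not yet change the picture of the series, which remains largely defined by one assay limit: the limit of > 100000 nM in this assay, at which 3 of the 4 values shown sit.

As far as these compounds go, the size of the true gap between the 3-methylphenyl and 4-ethoxyphenyl groups stays open, as does whether the ethoxy group or the shift in its place on the ring accounts for the reading. Also open, from the compounds shown here alone, is whether a longer chain such as butoxy, an amine or a carboxylic acid in place of the 4-ethoxyphenyl ether would bring the number clearly lower in this assay.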